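A few compounds are considered here, and "the series" means these few. Any claim that something is new, unique, unknown or untested is made for them only; others in the source may bear on it.

Measured so far in an assay on LtK cells with ATP-sensitive inward rectifier potassium channel 11 (Homo sapiens) as the target; a lower number here means that less compound is needed, a higher number that more compound is needed for the effect:
compound 1, `CC(C)C(=O)Nc1c(C(O)(C(F)(F)F)C(F)(F)F)ccc2ccccc12`, gives 6630 nM;
compound 2, `CCC(C)C(=O)Nc1c(C(O)(C(F)(F)F)C(F)(F)F)ccc2ccccc12`, gives 177000 nM;
compound 3, `O=C(Nc1c(C(O)(C(F)(F)F)C(F)(F)F)ccc2ccccc12)C1CCC1`, gives 45 nM.

Compound 3 holds the lowest number of the three, the steps of a 150-fold lower number from compound 1 to compound 3 (2.17 log units; beyond the scatter) and a 3900-fold lower number from compound 2 to compound 3 (3.59 log units; beyond the scatter) both lying beyond the scatter. Compound 4, `O=C(CCc1ccccc1)Nc1c(C(O)(C(F)(F)F)C(F)(F)F)ccc2ccccc12`, differs from compound 3 by phenethyl in place of cyclobutyl on a carbonyl carbon. Going by the values given here, no measured step covers a phenethyl group. The nearest are a 150-fold lower number from compound 1 to compound 3 (2.17 log units; beyond the scatter) and a 27-fold higher number from compound 1 to compound 2 (1.43 log units; beyond the scatter), both large: the ring gave the low number, the longer open chain the high one. Phenethyl is again no ring, so in this assay a higher number than for compound 3 is expected, its size uncertain. Compound 4 is estimated at 600 nM, range 60 nM to 6000 nM, an expected step of a 13-fold higher number from compound 3 to compound 4 (1.12 log units; beyond the scatter).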

Compound 4, half-maximal effective concentration: 1750 nM
Beside the measured number, compound 4's estimate is 2.9-fold (0.46 log units) below it; low and high end bracket the measured number.
By their numbers in this assay, from the lowest: compound 3; then compound 4; then compound 1; then compound 2.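

In this assay, phenethyl on the carbonyl carbon gives a 39-fold higher number from compound 3 to compound 4 (1.59 log units; beyond the scatter) and so loses much ground against cyclobutyl, while a 100-fold lower number from compound 2 to compound 4 (2.00 log units; beyond the scatter) and a 3.8-fold lower number from compound 1 to compound 4 (0.58 log units; beyond the scatter) show it still improving on both open alkyl groups. The number therefore does not simply follow the size of the group here, and an aromatic ring at the end of a chain is compatible with a number between those of the cyclobutyl and isopropyl amides. No measurement at hand explains these differences.

Still open, as far as these compounds go, is whether a cyclopentyl or cyclopropyl group would match cyclobutyl. A benzyl group would show how much the chain length in phenethyl matters.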